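Ethoxycarbonyl on the Amine Nitrogen of Compound 2

The source may hold more compounds than are shown below. What is called first, only, known or untested is meant among the compounds shown, and "the series" means these compounds.

Of the compounds shown here, two have so far been measured in an assay on COS-7 cells for inhibition of patatin-like phospholipase domain-containing protein 2 (Mus musculus), tested at 200 uM; a lower number here means less inhibition, a higher number more inhibition at the concentration tested (going by the name of the read-out). Compound 1 `CCOC(=O)C1CCCC(c2ccc(OCC)cc2)N1` gives 48%. Compound 2 `CN(C)c1ccc(-c2cccc(N)c2)cc1` gives 70%, the higher of the two numbers, and its gap to compound 1 lies beyond the usual scatter of this assay.

Compound 3 `CCOC(=O)Nc1cccc(-c2ccc(N(C)C)cc2)c1` is the next compound to be tested. It differs from compound 2 in a single place: ethoxycarbonyl in place of hydrogen on a nitrogen on an aromatic ring. Within the data shown here, no pair of measured compounds shows this change, so there is no measured step to say how this assay answers an ethoxycarbonyl on that nitrogen; the expectation rests only on the number of compound 2 and on the change itself.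

The step is expected to read a number 10 percentage points lower from compound 2 to compound 3 (within the scatter), a modest fall that stays near the edge of the scatter. For compound 3 the estimate in this assay is 60%, within a range from 35% to 85%.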

Compound 3, a percentage reported as inhibition, at one concentration (the size of the read-out at that concentration, not a potency): 93%
Beside the measured number, compound 3's estimate is 33 percentage points below it; measured number outside the range, above it.
By their numbers in this assay, from the lowest: compound 1; then compound 2; then compound 3.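

In this assay the nitrogen on an aromatic ring of compound 2 takes ethoxycarbonyl in place of hydrogen with no loss of inhibition at the concentration tested, and the change instead gives a number 23 percentage points higher from compound 2 to compound 3 (beyond the scatter). On this core, then, the free amino group is not required for the read-out, and (ethoxycarbonyl)amino reads higher than amino. Nothing available offers an explanation for this rise.

On these data alone, whether the gain belongs to the whole ethoxycarbonyl group or to only part of it remains open: an acetyl, a methoxycarbonyl or a longer alkoxycarbonyl chain on that nitrogen would begin to separate the carbonyl from the chain. Also open, as far as these compounds go, is whether the dimethylamino group of compound 3 contributes to this reading, which a methoxy group or a plain hydrogen in its place would test.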